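Carboxy for Bromo on a Sulfonyl Hydrazide Scaffold

The source may report more compounds than this note shows. Statements on the series, on what has been measured and on what is new or still open speak of the compounds shown alone.

Three hydrazide sulfonamides have been examined in an assay on HeLa cells for inhibition of Indoleamine 2,3-dioxygenase 1 (Homo sapiens), read by spectrophotometry, with a stated time of 24 h; a lower number here means that less compound is needed, a higher number that more compound is needed for the effect. Compound 1, with structure `CC(=O)Nc1ccc(S(=O)(=O)NNc2ccc(S(N)(=O)=O)cc2)cc1`, gives 3120 nM. Compound 2, `CC(=O)Nc1ccc(S(=O)(=O)NNc2ccc(Br)c(F)c2)cc1`, gives 187 nM. Compound 3, `O=S(=O)(NNc1ccc(Br)cc1)c1ccc(Br)cc1`, gives 374 nM in this assay; this is the second highest of the three numbers, its gap to compound 2 lying within the scatter while its gap to compound 1 lies beyond it.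

Compound 4, `O=C(O)c1ccc(S(=O)(=O)NNc2ccc(Br)cc2)cc1`, differs from compound 3 in one place: carboxy in place of bromo on an aromatic carbon. For the measured compounds named here, no measured pair shows this exact change, so the expectation rests on the set as a whole, in which the bromo-bearing compounds 2 and 3 sit at the lower end of the range, and compound 1 gives 3120 nM at the upper end. From this, compound 4 is expected to need more compound than compound 3, with a step of a 4.0-fold higher number from compound 3 to compound 4 (0.60 log units; beyond the scatter) that goes beyond the scatter. The estimate for compound 4 in this assay is 1500 nM, within a range from 400 nM to 6000 nM.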

Compound 4, half-maximal effective concentration: 172 nM
Estimate against measurement, compound 4: 8.7-fold (0.94 log units) above, outside the stated range (below it).
By their numbers in this assay, from the lowest: compounds 4, 2 and 3 (each within the scatter of the next, the first and the last beyond it); then compound 1.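

In this assay, carboxy in place of bromo on an aromatic carbon, para to a large group, comes with a 2.2-fold lower number from compound 3 to compound 4 (0.34 log units; beyond the scatter). For the compounds shown here, this is the first single change that can be read in the set, and it shows that bromo is not needed at this position: carboxy, with more heavy atoms and with a hydrogen-bond donor and acceptor that bromo lacks, is accepted there with no rise in the number. Nothing available explains why this exchange lowers the number.

From the compounds shown here alone, what a methyl ester, a primary amide or an amine would give at this position remains open. So does whether the same exchange would give a like step on the core of compound 2, which carries fluoro as well as bromo.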